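The source may report more compounds than this note shows. Statements on the series, on what has been measured and on what is new or still open speak of the compounds shown alone.

Compound 1 `O=S(=O)(c1ccc(F)cc1)c1cnc2cc(F)ccc2c1-c1cccc(F)c1` is the starting point here. Among the measured compounds shown here, in an ADME assay on microsomes from liver (Homo sapiens) for metabolic stability, tested at 2.5 uM (a higher number here means faster removal of the compound, a lower number slower removal), compound 1 gives 0.95 mL/min, the lowest of the three numbers so far. Compound 3 `O=S(=O)(c1cc(Cl)cc(Cl)c1)c1cnc2c(F)cccc2c1-c1cccc(Cl)c1` comes nearest, and in this assay compound 3 gives 1.2 mL/min, a gap that lies within the usual scatter, so the two cannot be ranked. Compound 2 `COc1cccc(S(=O)(=O)c2cnc3cc(F)ccc3c2-c2cccc(Cl)c2)c1` lies furthest away: in this assay compound 2 gives 2.97 mL/min, a gap beyond the scatter.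

The next compound is compound 4 `COc1ccc(S(=O)(=O)c2cnc3cc(F)ccc3c2-c2cccc(F)c2)cc1Cl`. It differs from compound 1 in one place: 3-chloro-4-methoxyphenyl in place of 4-fluorophenyl on a sulfonyl sulfur. For the measured compounds named here, no measured pair shows this exact change, so the expectation rests on the spread seen across compound 1, compound 3 and compound 2 alone. A modest rise in this assay from compound 1 to compound 4 is expected, probably no larger than the distance from compound 1 to compound 2, though it may also stay within the scatter. The expected step is a 1.9-fold higher number from compound 1 to compound 4 (0.28 log units; within the scatter). Compound 4 is estimated at 1.8 mL/min, with a likely range from 0.9 mL/min to 3.6 mL/min.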

Compound 4, intrinsic clearance in a liver preparation (reported as CLH), per the amount of preparation that the assay uses: 2.08 mL/min
Beside the measured number, compound 4's estimate is 1.2-fold (0.06 log units) below it; measured number inside the range.
By their numbers in this assay, from the lowest: compounds 1, 3, 4 and 2 (each within the scatter of the next, the first and the last beyond it).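

Among the compounds shown here, this is the first pair that differs in one place only, so a change on the sulfonyl sulfur can be read on its own. In this assay, 3-chloro-4-methoxyphenyl in place of 4-fluorophenyl gives a 2.2-fold higher number from compound 1 to compound 4 (0.34 log units; beyond the scatter) and shows that the group at this position can move the number beyond the usual scatter, although only modestly. No measurement shown here explains why the number rises.

From the compounds shown here alone, the new group differs from the old one in two ways at once, as it carries both a chlorine and a methoxy group, and it remains open which of them accounts for the step, or whether both are needed. Also open, going by these compounds, is how this assay would respond to an amine or a carboxylic acid on that ring.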